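One Side Group Exchanged in a Receptor Agonist Series

A few compounds are considered here, and "the series" means these few. Any claim that something is new, unique, unknown or untested is made for them only; others in the source may bear on it.

Compound 1 `CC(C)C(C(N)=O)c1ccc(Cl)cc1` is the smallest member. In a functional assay on CHO cells for agonist activity at Free fatty acid receptor 2 (Homo sapiens), read by cAMP accumulation (on this read-out lower numbers stand for smaller maximal responses and higher numbers for larger maximal responses), compound 1 reaches only a limit, < 30% (the limit of < 30% in this assay, at which 1 of the 3 values shown sits). Compound 2 `CC(C)(C)[C@H](C(=O)Nc1ncc(Br)s1)c1ccc(Cl)cc1` gives 95% in this assay. Compound 3 `CC(C)(C)[C@H](C(=O)Nc1ncc(Cc2ccc(Cl)cc2)s1)c1ccc(Cl)cc1` gives 100% in this assay; of the two numbers this is the larger, but the step of a number 5 percentage points higher from compound 2 to compound 3 (within the scatter) lies within the scatter, so compound 2 and compound 3 cannot be separated. Compound 4 `CC(C)(C)[C@H](C(=O)Nc1ncc(C(O)(C(F)(F)F)C(F)(F)F)s1)c1ccc(Cl)cc1` differs from compound 3 in one place: 2,2,2-trifluoro-1-hydroxy-1-(trifluoromethyl)ethyl in place of 4-chlorobenzyl on an aromatic carbon. Among the measured compounds shown here, the only measured change at that position, a number 5 percentage points higher from compound 2 to compound 3 (within the scatter), stayed within the scatter, so no step beyond the scatter is expected in this assay. Compound 4 is therefore expected to reach 95%, between 70% and 105%, an estimated step of a number 5 percentage points lower from compound 3 to compound 4 (within the scatter).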

Compound 4, largest response reached (reported as efficacy), in percent of the reference or control that the assay uses: 113%
Beside the measured number, compound 4's estimate is 18 percentage points below it; the measured number lies above the stated range.
By their numbers in this assay, from the lowest: compounds 2 and 3 (each within the scatter of the next); then compound 4. At a limit, below all of these: compound 1.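

Changing the group on the aromatic carbon next to the ring sulfur can move the maximal response after all. In this assay, 2,2,2-trifluoro-1-hydroxy-1-(trifluoromethyl)ethyl gives a number 13 percentage points higher from compound 3 to compound 4 (beyond the scatter) and, in place of bromo, a number 18 percentage points higher from compound 2 to compound 4 (beyond the scatter). So this group, which has no ring but has a hydrogen-bond donor, exceeds both bromo and 4-chlorobenzyl, two groups that could not be separated, yet nothing measured here explains the gain.

The compounds shown leave open whether the hydroxyl or the trifluoromethyl groups matter more, and how a carboxylic acid or an amine would compare at this position.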